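The compounds below may be only part of what the source reports. "The series", "measured", "known", "first", "only" and "open" are said of these compounds alone.

Measured in an ADME assay on HeLa Rh cells (Homo sapiens) for cytotoxicity, read by microscopy; a lower number here means that less compound is tolerated, a higher number that more compound is tolerated:

Compound 1, `COc1cc(CC(O)c2ccc(-c3ccc(C#N)cc3)cc2)c([N+](=O)[O-])cc1OC`, gives 4700 nM.
Compound 2, `COc1cc(CC(O)c2ccc(-c3ccc(Br)cc3)cc2)c([N+](=O)[O-])cc1OC`, gives 4300 nM.
Compound 3, `COc1cc(CC(O)c2ccc(-c3cccc(C#N)c3)cc2)c([N+](=O)[O-])cc1OC`, gives 5200 nM.

On these numbers compound 3 cannot be set apart from the other two: a 1.1-fold higher number from compound 1 to compound 3 (0.04 log units; within the scatter) and a 1.2-fold higher number from compound 2 to compound 3 (0.08 log units; within the scatter), both inside the scatter of repeated measurements. The three compounds share one core and differ only in the group carried on the outer aromatic ring.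

Compound 4, `COc1cc(CC(O)c2ccc(-c3cccc([N+](=O)[O-])c3)cc2)c([N+](=O)[O-])cc1OC`, continues this series. Its change from compound 3 is nitro in place of cyano on an aromatic carbon.

The steps measured so far all swap one such group for another on that outer ring, and none of them moved this assay beyond the scatter: a 1.1-fold lower number from compound 1 to compound 2 (0.04 log units; within the scatter), a 1.1-fold higher number from compound 1 to compound 3 (0.04 log units; within the scatter) and a 1.2-fold higher number from compound 2 to compound 3 (0.08 log units; within the scatter). The swap of cyano for nitro is a change of the same kind, so no step beyond the scatter is expected in either direction.

Compound 4 is therefore estimated at about 5200 nM, with a likely range from 2600 nM to 10400 nM. This estimate corresponds to a step of no change at the digits printed from compound 3 to compound 4 (within the scatter), which is expected to remain within the scatter.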

Compound 4, half-maximal cytotoxic concentration: 5500 nM
For compound 4 the middle estimate is 1.1-fold (0.02 log units) below the measured one; low and high end bracket the measured number.
By their numbers in this assay, from the lowest: compounds 2, 1, 3 and 4 (each within the scatter of the next).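

In this assay, swapping cyano for nitro on this outer ring, meta to a large group, gives a 1.1-fold higher number from compound 3 to compound 4 (0.02 log units; within the scatter) even though nitro brings more heavy atoms and hydrogen-bond acceptors. The comparisons with the two para-substituted compounds also stay inside the scatter, with a 1.3-fold higher number from compound 2 to compound 4 (0.11 log units; within the scatter) and a 1.2-fold higher number from compound 1 to compound 4 (0.07 log units; within the scatter) so no change of group on this ring has yet set any of the four compounds apart. No supporting evidence is available to explain this flat result.

As far as these compounds go, whether a different kind of group on this ring, such as an amine or a carboxylic acid, would move the tolerated concentration remains open. The shared core is the same in all four compounds, so what a change there would do is also unknown.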